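From Trifluoromethoxy to Isopropoxy: An Expected Half-Life

The compounds below may be only part of what the source reports. "The series", "measured", "known", "first", "only" and "open" are said of these compounds alone.

Compound 1 `CCc1nc(-c2ccc(OC(F)(F)F)cc2OC)c(CC)nc1NC(CC)CC`: 0.217 h
Compound 2 `CCc1nc(-c2ccc(OC(F)(F)F)cc2OC)c(OC)nc1NC(CC)CC`: 0.867 h

Both compounds were measured in an in vitro ADME assay on microsomes (Homo sapiens) for metabolic stability; a lower number here means that the compound disappears faster, a higher number that the compound lasts longer. Compound 1 gives 0.217 h, the lower of the two numbers, and compound 2 gives 0.867 h. The next compound to be measured is compound 3 `CCc1nc(-c2ccc(OC(C)C)cc2OC)c(CC)nc1NC(CC)CC`, which keeps the core of compound 1 and changes one group: isopropyl in place of trifluoromethyl on an oxygen on an aromatic ring. In words, isopropyl stands in place of trifluoromethyl on an oxygen on an aromatic ring, so trifluoromethoxy becomes isopropoxy.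

Among the compounds with values here, only one measured step is available, a 4.0-fold higher number from compound 1 to compound 2 (0.60 log units; beyond the scatter). It puts methoxy in place of ethyl on an aromatic carbon and leaves the trifluoromethoxy group untouched, so it bears on the new change only loosely. It does show that a single exchange can move this assay by a modest amount. Within the data shown here, no measured step covers the exchange in compound 3, so the direction is a judgement, and a small fall is expected, possibly within the scatter. The expected step is a 1.4-fold lower number from compound 1 to compound 3 (0.16 log units; within the scatter). For compound 3 the estimated half-life is 0.15 h, with an expected range from 0.07 h to 0.32 h.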

Compound 3, half-life: 0.183 h
Compound 3: middle estimate off by 1.2-fold (0.09 log units), on the low side; measured number inside the range.
By their numbers in this assay, from the lowest: compounds 3 and 1 (each within the scatter of the next); then compound 2.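

In this assay, within the data shown here, the exchange of trifluoromethyl for isopropyl on an oxygen on an aromatic ring gives a 1.2-fold lower number from compound 1 to compound 3 (0.07 log units; within the scatter) and so, unlike the earlier compounds, provides a first reading at this place: the swap of a fluorine-bearing group for an all-carbon one does not move the number beyond the scatter. The only step beyond the scatter remains a 4.0-fold higher number from compound 1 to compound 2 (0.60 log units; beyond the scatter), which lies at a different place in the molecule, so among the compounds shown, only the exchange of ethyl for methoxy on an aromatic carbon changes the half-life measurably. The data shown offer no measured explanation for either result.

It remains open whether the step from ethyl to methoxy would hold on a compound that carries isopropoxy rather than trifluoromethoxy, as each change is shown on the core of compound 1 alone. Also open is how a longer chain or a difluoromethyl group on the same oxygen would read in this assay, as the two groups shown do not settle that.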